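This account rests on a few compounds, and the source may have more. Where it says the series, first, only, none or still open, it means among the compounds named here.

Compound 1, `O=C(CCSc1nc2cc(F)ccc2o1)N1CCCC1`, and compound 2, `O=C(CCNc1nc2cc(Cl)ccc2o1)N1CCCC1`, share a core and differ in a few places. In an ADME assay on microsomes from liver (Mus musculus) for metabolic stability, read by LC-MS, using NADPH, with a stated time of 45 min, tested at 0.5 uM (a lower number here means slower removal, a higher number faster removal of the compound), compound 1 gives 115 mL/min/g, and compound 2 gives 81.1 mL/min/g; the two numbers lie within the usual scatter of each other, so neither can be called faster or slower. Compound 3, `COc1ccc2oc(SCCC(=O)N3CCCC3)nc2c1`, has not yet been measured. Its change from compound 1 is methoxy in place of fluoro on an aromatic carbon. Within the data shown here, with no comparable step among the measured compounds, the expected step of a 1.2-fold higher number from compound 1 to compound 3 (0.09 log units; within the scatter) is small and not beyond the scatter. Compound 3 is therefore estimated at 140 mL/min/g, with a range from 70 mL/min/g to 280 mL/min/g.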

Compound 3, intrinsic clearance in a liver preparation (reported as CLH), per the amount of preparation that the assay uses: 198 mL/min/g
Compound 3: the middle estimate sits 1.4-fold (0.15 log units) below what was measured; the range from low to high includes it.
By their numbers in this assay, from the lowest: compounds 2, 1 and 3 (each within the scatter of the next, the first and the last beyond it).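

Methoxy in place of fluoro on an aromatic carbon of the shared core is the first single-place step available here, and in this assay it gives a 1.7-fold higher number from compound 1 to compound 3 (0.24 log units; within the scatter) for this position. This swap, which brings in one more heavy atom and a hydrogen-bond acceptor, therefore cannot be told apart from repeat variation. Nothing available explains the result.

Going by these compounds, whether a nitrile or a carboxylic acid on this same carbon would give a step beyond the scatter stays open. So does whether methoxy for a halogen would give a similar step on the core of compound 2.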